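The source may report more compounds than this note shows. Statements on the series, on what has been measured and on what is new or still open speak of the compounds shown alone.

Compound 3, `Cc1nsc2[nH]c(SCc3ccccc3)nc12`, is the strongest of the three compounds measured in a functional assay on HFF cells (Homo sapiens) for inhibition; on this read-out higher numbers stand for weaker inhibition and lower numbers for stronger inhibition: its value of 10000 nM is the lowest of the three. The next one up is compound 2, `CSc1nc2c(C)nsc2[nH]1`, whose value in this assay is 26000 nM, and the furthest is compound 1, `Cc1nsc2[nH]cnc12`, which gives 32000 nM in this assay. Both gaps to compound 3 are beyond the usual scatter.

The next compound keeps the core of compound 3 and its benzylsulfanyl group, but changes one place: 4-hydroxy-5-(hydroxymethyl)oxolan-2-yl in place of hydrogen on an aromatic nitrogen. The result is compound 4, `Cc1nsc2c1nc(SCc1ccccc1)n2[C@H]1C[C@H](O)[C@@H](CO)O1`.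

Going by the values given here, no measured pair speaks directly to this change. Among the compounds with values here, the only single-place step recorded, a 1.2-fold lower number from compound 1 to compound 2 (0.09 log units; within the scatter), concerns a methylsulfanyl group on an aromatic carbon, not a group on an aromatic nitrogen, and it lies within the scatter, so it gives no guidance on the size or direction of the present step. The gap from compound 2 to compound 3 shows that a larger group at the carbon site lowered the number, but that is a different position again.

Within the data shown here, with no precedent, the expectation is cautious: compound 4 is estimated at 6000 nM, with a range from 1500 nM to 30000 nM, which would mean an expected step of a 1.7-fold lower number from compound 3 to compound 4 (0.22 log units; within the scatter).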

Compound 4, half-maximal inhibitory concentration: > 100000 nM
Compound 4: no number, only a limit; the forecaster's own chance of this, stated with the estimate: 10%; at least 16-fold (1.22 log units) between middle value and limit.
By their numbers in this assay, from the lowest: compound 3; then compounds 2 and 1 (each within the scatter of the next). At a limit, above all of these: compound 4.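

In this assay compound 4 reads > 100000 nM, which is a limit of the assay and not a number. Until now, the only changes shown were on an aromatic carbon, so this is the first view of what happens at the aromatic nitrogen: with 4-hydroxy-5-(hydroxymethyl)oxolan-2-yl in place of hydrogen there, the result is an at least 10-fold higher number from compound 3 to compound 4 (1.00 log units; beyond the scatter). Inhibition by the benzylsulfanyl compound is therefore sensitive to this change on the nitrogen, and the direction of the step is clear, but its printed size is only a lower bound and the true size cannot be read: the limit of > 100000 nM in this assay, at which 1 of the 4 values shown sits.

With only hydrogen and this one substituted ring on that nitrogen, the compounds shown cannot separate the contribution of the ring from that of its hydroxy and hydroxymethyl groups. They also leave open how the number would respond to a plain ethyl chain, an amine or a carboxylic acid at the same nitrogen, and whether the same change would have a similar effect on compound 1 or compound 2.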